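The source may hold more compounds than are shown below. What is called first, only, known or untested is meant among the compounds shown, and "the series" means these compounds.

Compound 3 `CC(=N)N1CCC(C(CS)C(=O)O)CC1` carries, on the ring nitrogen of the shared core of compound 1 `O=C(O)C(CS)C1CCNCC1`, a group of 3 heavy atoms (2 carbon, 1 nitrogen; no ring). In an assay on isolated protein for inhibition of carboxypeptidase B (Sus scrofa) (on this read-out higher numbers stand for weaker inhibition and lower numbers for stronger inhibition), compound 3 gives 1040 nM, the highest of the two single numbers here; compound 1 gives 195 nM, and the step of a 5.3-fold higher number from compound 1 to compound 3 (0.73 log units; beyond the scatter) shows that this group raised the number beyond the usual scatter. Compound 2 `N=C(N)N1CCCC(C(CS)C(=O)O)C1`, with a different ring and group, has several entries in this assay, 3 nM; 38 nM (2 entries), which are spread widely the several entries of compound 2 in this assay, 3 nM; 38 nM (2 entries) and give no single number.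

Compound 4 `NCC(=O)N1CCC(C(CS)C(=O)O)CC1` differs from compound 3 in one place: a group of 4 heavy atoms (2 carbon, 1 nitrogen, 1 oxygen; no ring) in place of a group of 3 heavy atoms (2 carbon, 1 nitrogen; no ring), on an amine nitrogen in a ring. Going by the values given here, only the step from compound 1 to compound 3 bears on this change, and it removes the group that step introduced while bringing in another of similar size, so the direction is uncertain. A step near the scatter, or slightly downward, is therefore expected, a 1.7-fold lower number from compound 3 to compound 4 (0.24 log units; within the scatter). For compound 4 the estimate in this assay is 600 nM, within a range from 120 nM to 3000 nM.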

Compound 4, half-maximal inhibitory concentration: > 30000 nM
Compound 4: only a limit was reported; the forecaster's own chance of this, stated with the estimate: 5%; at least 50-fold (1.69 log units) between middle value and limit.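

In this assay compound 4 gives > 30000 nM, which is a limit of the assay and not a number. Even so, the change reads as an at least 28-fold higher number from compound 3 to compound 4 (1.46 log units; beyond the scatter), and against the hydrogen of the shared core as an at least 150-fold higher number from compound 1 to compound 4 (2.18 log units; beyond the scatter), both larger than the modest 5.3-fold higher number from compound 1 to compound 3 (0.73 log units; beyond the scatter). On this amine nitrogen, then, the choice of group can matter far more than the first step suggested, with the (aminomethyl)carbonyl group going with much weaker inhibition than either hydrogen or the group of compound 3.

The compounds shown do not tell whether the carbonyl or the amine of this group goes with the loss, which a plain acetyl group or a longer amino chain on the same nitrogen could help separate. Compound 2 differs from these compounds in more than one place and offers no single reference value: the several entries of compound 2 in this assay, 3 nM; 38 nM (2 entries)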